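A few compounds are considered here, and "the series" means these few. Any claim that something is new, unique, unknown or untested is made for them only; others in the source may bear on it.

Compounds measured in a functional assay on Huh-5-2 cells (Homo sapiens), read by MTT assay; on this read-out higher numbers stand for lower toxicity in this test and lower numbers for higher toxicity in this test:
- compound 1 `O=C(O)c1ccc2c(c1)nc(-c1ccc(OCc3ccccc3-c3ccc(Cl)cc3)cc1)n2C1CCCCC1`: 25000 nM
- compound 2 `O=C(O)c1ccc2c(c1)nc(-c1ccc(OCc3cccnc3-c3ccc(Cl)cc3)cc1)n2C1CCCCC1`: > 50000 nM
- compound 3 `O=C(O)c1ccc2c(c1)nc(-c1ccc(OCc3cc(C(=O)N4CCCCC4)ccc3-c3ccc(Cl)cc3)cc1F)n2C1CCCCC1`: 24000 nM

Compound 2 reads > 50000 nM, which is a limit of the assay and not a number. Compound 3, at 24000 nM, lies within the scatter of compound 1, at 25000 nM. Compound 4 `CN(C)C(=O)Nc1ccc(-c2ccc(Cl)cc2)c(COc2ccc(-c3nc4cc(C(=O)O)ccc4n3C3CCCCC3)c(F)c2)c1` is still unmeasured and differs from compound 3 by one change: (dimethylcarbamoyl)amino in place of (piperidin-1-yl)carbonyl on an aromatic carbon. Going by the values given here, no measured step shows what this change does, so none beyond the scatter is expected in this assay. The estimated move, a 1.1-fold higher number from compound 3 to compound 4 (0.03 log units; within the scatter), is expected to stay small. For compound 4, the expected value is 26000 nM, with an estimated range of 12000 nM to 50000 nM.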

Compound 4, half-maximal cytotoxic concentration: 25000 nM
The estimate for compound 4 lay 1.0-fold (0.02 log units) above the measured number; measured number inside the range.
By their numbers in this assay, from the lowest: compounds 3, 1 and 4 (each within the scatter of the next). At a limit, above all of these: compound 2.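

In this assay the exchange of (piperidin-1-yl)carbonyl for (dimethylcarbamoyl)amino, on an aromatic carbon para to a 4-chlorophenyl group, comes out as a 1.0-fold higher number from compound 3 to compound 4 (0.02 log units; within the scatter). Going by these compounds alone, this is the first step that can be read at this position: losing the six-membered non-aromatic ring and gaining a hydrogen-bond donor go with no difference beyond the scatter. Nothing shown gives a cause for this result. On these data alone, whether a primary amine, a carboxylic acid or a longer alkyl chain on the same carbon would also read within the scatter of compound 3 stays open.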